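Bromo on the benzyl ring of a methoxychalcone triazole

The source may report more compounds than this note shows. Statements on the series, on what has been measured and on what is new or still open speak of the compounds shown alone.

Three compounds share a chalcone core carrying a benzyl-triazole ether. Compound 1 `O=C(/C=C/c1ccc(OCc2cn(Cc3ccccc3)nn2)cc1)c1ccc(Br)cc1` gives 34% in a functional assay on A549 cells (Homo sapiens) for inhibition, read by MTT assay, with a stated time of 48 h, tested at 10 uM; on this read-out lower numbers stand for less inhibition of growth and higher numbers for more inhibition of growth at the one concentration tested. Compound 2 `O=C(/C=C/c1ccc(OCc2cn(Cc3ccccc3F)nn2)cc1)c1ccc(Br)cc1` gives 38%, a difference of a number 4 percentage points higher from compound 1 to compound 2 (within the scatter). Compound 3 `COc1ccc(C(=O)/C=C/c2ccc(OCc3cn(Cc4ccccc4)nn3)cc2)cc1` gives 44%, a difference of a number 10 percentage points higher from compound 1 to compound 3 (within the scatter); its value cannot be told apart from that of compound 2 either. Compound 4 `COc1ccc(C(=O)/C=C/c2ccc(OCc3cn(Cc4cccc(Br)c4)nn3)cc2)cc1` differs from compound 3 by bromo in place of hydrogen on an aromatic carbon. Going by the values given here, the one measured step that places a halogen on the same benzyl ring, from compound 1 to compound 2, was small, and the step from compound 1 to compound 3 was also within the scatter, so in this assay no step beyond the scatter is expected, with a number 2 percentage points higher from compound 3 to compound 4 (within the scatter). Compound 4 is therefore estimated at 46%, between 30% and 62%.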

Compound 4, percent growth inhibition at one concentration: 47%
The estimate for compound 4 lay 1 percentage points below the measured number, and the stated range covers the measured number.
By their numbers in this assay, from the lowest: compounds 1, 2, 3 and 4 (each within the scatter of the next, the first and the last beyond it).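

In this assay, going by these compounds alone, the change from benzyl to 3-bromobenzyl gives a number 3 percentage points higher from compound 3 to compound 4 (within the scatter) and so shows that this place on the benzyl ring takes a bromo with no step that can be told from the scatter. Alongside a number 4 percentage points higher from compound 1 to compound 2 (within the scatter) for fluoro, it makes two halogen steps on that ring, one in each series, and neither lies beyond the scatter. Nothing shown gives a reason for either step. Open, going by these compounds, is whether an amine or a carboxylic acid on this ring, or a longer chain in place of benzyl, would move the number beyond the scatter.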